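The source may report more compounds than this note shows. Statements on the series, on what has been measured and on what is new or still open speak of the compounds shown alone.

In a functional assay on a cell-free system (plasma, Oryctolagus cuniculus) for inhibition, with stated times of 5 min, 1 min and 6 min (a higher number here means a weaker inhibitor, a lower number a stronger inhibitor), compound 2 `CCOC(=O)c1c(C)nc(-c2cccc(C#N)c2)n1OCc1ccc(Cl)cc1` gives 6830 nM and compound 1 `CCOC(=O)c1c(C)nc(-c2cccc(C#N)c2)n1OCc1ccccc1F` gives 8990 nM. Among the compounds with values here, these two numbers lie within the usual scatter of each other, so compound 2 stands level with the only other measured compound. Compound 3 `CCOC(=O)c1c(C)nc(-c2cccc(C#N)c2)n1OCc1ccc(OC)cc1` differs from compound 2 in one group: methoxy in place of chloro on an aromatic carbon. Put simply, methoxy replaces chloro on an aromatic carbon, para to a large group. Within the data shown here, only one measured step offers guidance, a 1.3-fold lower number from compound 1 to compound 2 (0.12 log units; within the scatter). It placed 4-chlorophenyl where 2-fluorophenyl stood, and its size stayed within the scatter. Among the measured compounds shown here, no measured compound carries a methoxy group, so this guidance is thin, and no change beyond the scatter is expected. The expected step is a 1.1-fold higher number from compound 2 to compound 3 (0.04 log units; within the scatter). For compound 3, the estimated value is 7500 nM, with an expected range of 2800 nM to 20000 nM.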

Compound 3, half-maximal inhibitory concentration: 6830 nM
Beside the measured number, compound 3's estimate is 1.1-fold (0.04 log units) above it; the range from low to high includes it.
By their numbers in this assay, from the lowest: compounds 2, 3 and 1 (each within the scatter of the next).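

In this assay, methoxy in place of chloro, para to a large group, gives no change at the digits printed from compound 2 to compound 3 (within the scatter): trading one heavy atom for two and adding a hydrogen-bond acceptor leaves the read-out level at this position. The other new comparison, a 1.3-fold lower number from compound 1 to compound 3 (0.12 log units; within the scatter), also stays within the scatter, so 4-methoxyphenyl stands level with both 2-fluorophenyl and 4-chlorophenyl. Nothing measured here explains why these changes leave the numbers level.

Going by these compounds, with all three compounds level, it remains open whether any group at this position can shift the number beyond the scatter. On these data alone, how an amine, a carboxylic acid or a longer chain would read in this place also stays open, as does whether the flat result holds with other parts of the shared core changed.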